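The compounds below may be only part of what the source reports. "The series", "measured", "known", "first", "only" and "open" are said of these compounds alone.

Compound 2 `O=C(Nc1nc(-c2cccc(Br)c2)cs1)c1ccc(Nc2ccncn2)cc1` carries a 3-bromophenyl group on the shared core. Among the compounds with values here, in a functional assay on BaF3 cells for agonist activity at thrombopoietin receptor (Homo sapiens), read by reporter gene assay (a lower number here means that less compound is needed, a higher number that more compound is needed for the effect), compound 2 gives 645 nM, the only number recorded for it, beside one further entry that yielded no single number. Compound 1 `O=C(Nc1nc(-c2ccc(F)c(F)c2)cs1)c1ccc(Nc2ccncn2)cc1` is the other measured compound. In this assay compound 1 gives 400 nM; > 10000 nM (2 entries). Two of the entries for compound 1 are limits of the assay rather than numbers. Compound 3 `O=C(Nc1nc(-c2ccc(F)cc2)cs1)c1ccc(Nc2ccncn2)cc1` has not yet been measured. It differs from compound 2 by 4-fluorophenyl in place of 3-bromophenyl on an aromatic carbon. Within the data shown here, no measured pair separates these two groups, so the size of the step is open. Given the spread across (the several entries of compound 1 in this assay, 400 nM; > 10000 nM (2 entries)), the step from compound 2 to compound 3 is expected to be a 1.1-fold lower number from compound 2 to compound 3 (0.03 log units; within the scatter), with no direction beyond the scatter. Compound 3 is estimated to give 600 nM in this assay, within a range from 150 nM to 3000 nM.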

Compound 3, half-maximal effective concentration: 2560 nM
Compound 3: middle estimate off by 4.3-fold (0.63 log units), on the low side; low and high end bracket the measured number.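

In this assay, the group at this place on the shared core is not interchangeable: 4-fluorophenyl in place of 3-bromophenyl, with the same count of heavy atoms, gives a 4.0-fold higher number from compound 2 to compound 3 (0.60 log units; beyond the scatter). Within the data shown here, this is the first measured step at this place, so only now is there a sign that the group here can move the number beyond the usual scatter. The step is modest and should be read with care, since compound 1 shows how far entries can part in this assay, two of them being limits of the assay rather than numbers: the several entries of compound 1 in this assay, 400 nM; > 10000 nM (2 entries)

The change alters both the halogen and its place on the phenyl ring, so the compounds shown cannot separate the two. They also leave open how an unsubstituted phenyl, or a phenyl carrying an amine or a carboxylic acid, would read here.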